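Aryl urea series: 3-chlorophenyl in place of 4-methylphenyl

The source may report more compounds than this note shows. Statements on the series, on what has been measured and on what is new or still open speak of the compounds shown alone.

Compound 2 `Cc1ccc(NC(=O)NC2CC(C)(C)Oc3ccc(Cl)cc32)cc1` is the point of departure. In a functional assay (aorta) with Rattus norvegicus as the target (a lower number here means that less compound is needed, a higher number that more compound is needed for the effect), compound 2 gives > 30000 nM, which is a limit of the assay and not a number. Compound 1 `COc1cccc(NC(=O)NC2CC(C)(C)Oc3ccc(Cl)cc32)c1` carries 3-methoxyphenyl on the amide-type nitrogen where compound 2 carries 4-methylphenyl. In this assay compound 1 gives > 10000 nM, also a limit of the assay. The step that the two limits leave unreadable from compound 1 to compound 2 is thus of unreadable size, both values sitting at limits, the limit of > 10000 nM in this assay, at which 1 of the 2 values shown sits, and (the limit of > 30000 nM in this assay, at which 1 of the 2 values shown sits).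

Compound 3 `CC1(C)CC(NC(=O)Nc2cccc(Cl)c2)c2cc(Cl)ccc2O1` differs from compound 2 by 3-chlorophenyl in place of 4-methylphenyl on an amide-type nitrogen. Within the data shown here, only one measured step touches an aryl swap on this nitrogen, a step that the two limits leave unreadable from compound 1 to compound 2, and it cannot be read, so no direction is known for such a change in this assay. With both known compounds at limits, the expectation is that compound 3 stays near them. The expected step is an at least 1.2-fold lower number from compound 2 to compound 3 (0.07 log units; that floor lies within the scatter), with no shift beyond the scatter claimed. Compound 3 is estimated at 25000 nM, between 6000 nM and 100000 nM, and is most likely to be reported as a limit again.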

Compound 3, half-maximal effective concentration: > 30000 nM
Compound 3: no number, only a limit; the forecaster's own chance of this, stated with the estimate: 75%; middle value at least 1.2-fold (0.07 log units) from the limit.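

In this assay compound 3 gives > 30000 nM, a limit of the assay and not a number. The steps among compound 1, compound 2 and compound 3 cannot be read, as each of the three values is a limit. The compounds shown leave open whether any of these aryl groups on the amide-type nitrogen changes the half-maximal effective concentration in this assay, and in which direction.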